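This account rests on a few compounds, and the source may have more. Where it says the series, first, only, none or still open, it means among the compounds named here.

Measured so far:
Compound 1 `CC1(C)CCCC2=C1C[C@@H](C(=O)O)[C@H](c1ccccc1)C2`: > 23000 nM
Compound 2 `CON(C)C(=O)[C@H]1CC2=C(CCCC2(C)C)C[C@@H]1c1ccccc1`: > 23000 nM

Both values come from an assay on isolated protein for inhibition of Apoptosis regulator Bcl-2 (Homo sapiens), read by fluorescence polarization, with stated times of 5 min and 10 min; on this read-out lower numbers stand for stronger inhibition and higher numbers for weaker inhibition. For compound 1 the value > 23000 nM is a limit of the assay and not a number. For compound 2 the value > 23000 nM is likewise a limit of the assay and not a number. Compound 2 therefore stands at the limit of > 23000 nM in this assay, at which 2 of the 2 values shown sit, and its place among the numbers shown is known only to that extent.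

Compound 3 `CC1(C)CCCC2=C1C[C@H](C(=O)O)[C@@H](c1ccccc1)C2` differs from compound 2 in one place: hydroxy in place of methoxy(methyl)amino on a carbonyl carbon. Among the compounds with values here, no step between two measured compounds is available that could indicate the size or direction of the change to be expected from this replacement, and nothing among the measured values speaks for either a gain or a loss. The step from compound 2 to compound 3 is expected to be a step that the limit leaves unreadable from compound 2 to compound 3, that is, no change beyond the scatter, with the result most likely again a limit. Compound 3 is accordingly expected to give 30000 nM in this assay, within a range from 10000 nM to 100000 nM.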

Compound 3, inhibition constant: > 23000 nM
Compound 3: no number, only a limit; the forecaster's own chance of this, stated with the estimate: 80%; the middle value is on the limit's open side.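

In this assay compound 3 gives > 23000 nM, which is a limit and not a number. With compound 1 and compound 2 also at a limit, the steps to compound 3 from each of them cannot be read. The compounds shown leave open how strongly any of the three inhibits, and whether the mirror images compound 1 and compound 3 differ at all in this assay.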